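The source may hold more compounds than are shown below. What is called first, only, known or untested is meant among the compounds shown, and "the series" means these compounds.

Compound 1 `COc1ccc(C2CC(c3ccc(OCc4cn(CCNc5ccnc6cc(Cl)ccc56)nn4)c(OC)c3)=NN2C(C)=O)cc1OC` and compound 2 `COc1ccc(C2CC(c3ccc(OCc4cn(CCNc5ccnc6cc(Cl)ccc56)nn4)c(OC)c3)=NN2C(C)=O)cc1` share one core and differ by a single methoxy. In an ADME assay on HeLa cells (Homo sapiens) for cytotoxicity, read by trypan blue exclusion, with a stated time of 24 h (on this read-out lower numbers stand for stronger inhibition and higher numbers for weaker inhibition), compound 1 gives 42700 nM, while compound 2 gives 32800 nM; that change was a 1.3-fold lower number from compound 1 to compound 2 (0.11 log units; within the scatter). On these two numbers compound 2 cannot be set apart from compound 1, since their step lies within the scatter. Compound 3 `COc1ccc(C2CC(c3ccc(OCc4cn(CCNc5ccnc6cc(Cl)ccc56)nn4)cc3)=NN2C(C)=O)cc1` removes a further methoxy: hydrogen in place of methoxy on an aromatic carbon. Within the data shown here, the only comparable step, from compound 1 to compound 2, stayed within the scatter, so in this assay no step beyond the scatter is expected, a 1.2-fold lower number from compound 2 to compound 3 (0.07 log units; within the scatter). Compound 3 is therefore estimated at 28000 nM, between 12000 nM and 70000 nM.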

Compound 3, half-maximal inhibitory concentration: 29200 nM
Estimate against measurement, compound 3: 1.0-fold (0.02 log units) below; measured number inside the range.
By their numbers in this assay, from the lowest: compounds 3, 2 and 1 (each within the scatter of the next).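

Taking out this second methoxy, which sits ortho to a large group and meta to a large group, gives a 1.1-fold lower number from compound 2 to compound 3 (0.05 log units; within the scatter) in this assay. Hydrogen in place of methoxy has now stayed within the scatter at two different places on the shared core, not just at the one seen before. Nothing available explains why this swap leaves the number so little changed.

Only methoxy and hydrogen appear at this position. As far as these compounds go, whether an amine, a carboxylic acid or a longer chain such as butoxy here would give a step beyond the scatter remains open.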